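Swapping the chain stereocentre of compound 1

The source may report more compounds than this note shows. Statements on the series, on what has been measured and on what is new or still open speak of the compounds shown alone.

Among the measured compounds shown here, in an ADME assay for pharmacokinetics (on this read-out higher numbers stand for a longer-lived compound and lower numbers for a shorter-lived compound), compound 1 `C[C@@H](NC(=O)Nc1ccc2c(Cl)c(OCCSC(=N)N)oc(=O)c2c1)c1ccccc1` gives 1.03 h as the lower of the two numbers measured so far. Compound 2 `N=C(N)SCCCOc1oc(=O)c2cc(NC(=O)NCc3ccccc3)ccc2c1Cl` gives 2.47 h on the same read-out, and the gap between the two lies beyond the scatter. These two compounds differ in more than one place, so their gap cannot be assigned to any single change.

The next compound is compound 3 `C[C@H](NC(=O)Nc1ccc2c(Cl)c(OCCSC(=N)N)oc(=O)c2c1)c1ccccc1`, which has the same atoms and bonds as compound 1. The change is the two compounds have the same atoms and bonds; at least one stereo element is drawn with a configuration in one of them and without one in the other: 1 of 2 stereo elements differ; a stereocentre at a saturated chain carbon is drawn R in compound 1 and S in compound 3 and in it a stereocentre at a saturated chain carbon is drawn R in compound 1 and S in compound 3. For the measured compounds named here, no measured pair isolates a change of this kind, so the data offer neither a size nor a direction for it. No step beyond the scatter is therefore expected in this assay. The expectation stays anchored on compound 1 (1.03 h) as the only measured reference. The estimated move is a 1.1-fold higher number from compound 1 to compound 3 (0.03 log units; within the scatter) and it is expected to stay within the scatter. For compound 3 the estimate is 1.1 h with an expected range from 0.55 h to 2.2 h in repeat measurements.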

Compound 3, half-life: 0.933 h
The estimate for compound 3 lay 1.2-fold (0.07 log units) above the measured number; measured number inside the range.
By their numbers in this assay, from the lowest: compounds 3 and 1 (each within the scatter of the next); then compound 2.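

In this assay, among the compounds shown here, this is the first pair that differs in one place, and it gives a 1.1-fold lower number from compound 1 to compound 3 (0.04 log units; within the scatter), so the two configurations at this saturated chain carbon are not separated on this read-out. For this pair, swapping the stereocentre from R in compound 1 to S in compound 3 yields no step beyond the scatter, and the series now has a measured size for a change of this kind. The comparison rests on a single structural point: the fact that one of compounds 1 and 3 is drawn with a defined configuration and the other without, at the place where they differ.

The compounds shown leave open whether an ethyl group or a carboxylic acid in place of the methyl group at this stereocentre would give a step beyond the scatter in this assay. They also leave open whether the same swap would stay this small with a longer chain carrying the thiourea-derived end of the molecule, as one pair on the shared core sets no general rule.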